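Acyl variation on the aryloxypropyl-piperazine series

The source may report more compounds than this note shows. Statements on the series, on what has been measured and on what is new or still open speak of the compounds shown alone.

Two compounds have numbers in an assay on isolated protein for binding affinity to histamine H2 receptor (Homo sapiens); a lower number here means a stronger inhibitor, a higher number a weaker inhibitor. Compound 1 `CCCCCC(=O)c1ccc(OCCCN2CCN(CCCC)CC2)cc1` gives 7590 nM. Compound 2 `CCOC(=O)N1CCN(CCCOc2ccc(C(C)=O)cc2)CC1` gives 39800 nM, the highest of the two, with compound 1 a good way lower; the two differ at more than one place, so only the two values themselves are read. Compound 3 `C=C(C)C(=O)c1ccc(OCCCN2CCN(C(=O)OCC)CC2)cc1` is made from compound 2 by 1-methylethenyl in place of methyl on a carbonyl carbon, with 1-methylethenyl in place of methyl on a carbonyl carbon. Among the measured compounds shown here, no single-change step is known here, so the direction is uncertain; a modest shift toward a lower number is expected, a 1.6-fold lower number from compound 2 to compound 3 (0.20 log units; within the scatter), with compound 3 estimated at 25000 nM in this assay, within 8000 nM to 80000 nM.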

Compound 3, inhibition constant: 22400 nM
For compound 3 the middle estimate is 1.1-fold (0.05 log units) above the measured one, and the stated range covers the measured number.
By their numbers in this assay, from the lowest: compound 1; then compounds 3 and 2 (each within the scatter of the next).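

In this assay, 1-methylethenyl in place of methyl on a carbonyl carbon whose other neighbour is an aromatic carbon gives a 1.8-fold lower number from compound 2 to compound 3 (0.25 log units; within the scatter). Among the compounds shown here, this is the first single-change reading, and it shows that this position accepts the larger group with its double bond without a shift beyond the scatter. Nothing available bears on this result.

Open, from the compounds shown here alone, is whether 1-methylethyl, the same branch without the double bond, would read alike on this carbonyl carbon. Also open, going by these compounds, is whether phenyl or cyclopropyl there would move the number beyond the scatter.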